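The source may hold more compounds than are shown below. What is called first, only, known or untested is meant among the compounds shown, and "the series" means these compounds.

Of the compounds shown here, three from one series have been tested in an ADME assay on Vero cells (Chlorocebus sabaeus) for cytotoxicity, read by resazurin assay, with a stated time of 72 h; on this read-out higher numbers stand for weaker inhibition and lower numbers for stronger inhibition. Compound 1 `COc1ccc(C(=O)CCN2CCN(c3ccc(C(F)(F)F)cc3)CC2)cc1` gives 135000 nM in this assay. Compound 2 `COc1ccc(C(=O)CCN2CCN(c3ccc(Cl)cc3)CC2)cc1` carries chloro in place of trifluoromethyl on an aromatic carbon, and in this assay compound 2 gives 300000 nM; that single change made a 2.2-fold higher number from compound 1 to compound 2 (0.35 log units; beyond the scatter). Compound 3 `O=C(CCN1CCN(c2ccc(C(F)(F)F)cc2)CC1)c1ccc(F)c(F)c1` keeps the trifluoromethyl of compound 1 but has a different core; in this assay compound 3 gives 14000 nM, which amounts to a 9.6-fold lower number from compound 1 to compound 3 (0.98 log units; beyond the scatter). Compound 3 thus has the lowest number of the three, and its steps to compound 1 and to compound 2 both lie beyond the scatter.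

Compound 4 `O=C(CCN1CCN(c2ccc(Cl)cc2)CC1)c1ccc(F)c(F)c1` is not yet measured. It is related to compound 3 by chloro in place of trifluoromethyl on an aromatic carbon, and this is the same change that relates compound 2 to compound 1; in both cases the place is described in identical words, so it is the same change made on a second core. The two cores differ by 3,4-difluorophenyl in place of 4-methoxyphenyl on a carbonyl carbon. Going by the values given here, the only guide to how the change behaves is the pair already measured, where it gave a modest rise in the number. Among the compounds with values here, compound 4 is expected to show a step of a 2.2-fold higher number from compound 3 to compound 4 (0.35 log units; beyond the scatter) because the earlier pair showed a 2.2-fold higher number from compound 1 to compound 2 (0.35 log units; beyond the scatter), and there is no further pair to suggest the core alters this. Compound 4 is therefore estimated at 31000 nM, with a likely range from 12000 nM to 80000 nM.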

Compound 4, half-maximal inhibitory concentration: 86200 nM
For compound 4 the middle estimate is 2.8-fold (0.44 log units) below the measured one; measured number outside the range, above it.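

In this assay, chloro in place of trifluoromethyl again raises the number on the second core, with a 6.2-fold higher number from compound 3 to compound 4 (0.79 log units; beyond the scatter), so the direction of the change carries over but its size does not: the same change on two cores in this assay, a 2.2-fold higher number (0.35 log units; beyond the scatter) from compound 1 to compound 2 and a 6.2-fold higher number (0.79 log units; beyond the scatter) from compound 3 to compound 4, 2.8-fold (0.44 log units) apart, beyond the scatter of two such steps. Seen from the other side, 3,4-difluorophenyl in place of 4-methoxyphenyl lowers the number on the chloro compounds as well, with a 3.5-fold lower number from compound 2 to compound 4 (0.54 log units; beyond the scatter), and here too the size differs from that on the trifluoromethyl compounds: the same change on two cores in this assay, a 9.6-fold lower number (0.98 log units; beyond the scatter) from compound 1 to compound 3 and a 3.5-fold lower number (0.54 log units; beyond the scatter) from compound 2 to compound 4, 2.8-fold (0.44 log units) apart, beyond the scatter of two such steps. These two comparisons rest on the same four compounds and describe a single mismatch, so they show that the two changes do not add up simply in this small set, but they do not show why, nor how the chloro change would behave on a third core.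

The compounds shown leave open whether another group on the aromatic carbon, such as bromo or a nitrile, would follow the same direction on both cores. They also leave open whether a different group on the carbonyl carbon, such as an unsubstituted phenyl, or a longer chain between the carbonyl and the rest of the core, would keep the lower numbers seen with 3,4-difluorophenyl.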